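The source may hold more compounds than are shown below. What is called first, only, known or untested is meant among the compounds shown, and "the series" means these compounds.

Compound 2 `CN(C)C(=O)C[C@H](CSc1ccccc1)Nc1c(C(=O)N/N=C/c2cccnc2)cnc2c(C(F)(F)F)cccc12` carries a pyridin-3-yl group on a carbon with a double bond to nitrogen. In an ADME assay on Vero cells (Chlorocebus sabaeus) for cytotoxicity, read by MTT assay, with a stated time of 72 h (on this read-out higher numbers stand for weaker inhibition and lower numbers for stronger inhibition), compound 2 gives > 62.5 ug/mL, which is a limit of the assay rather than a number. Its neighbour compound 1 `CN(C)C(=O)C[C@H](CSc1ccccc1)Nc1c(C(=O)N/N=C/c2ccccc2F)cnc2c(C(F)(F)F)cccc12` differs only in bearing a 2-fluorophenyl group there. In this assay compound 1 gives > 62.5 ug/mL, likewise a limit. The step that the two limits leave unreadable from compound 1 to compound 2 is therefore unreadable, as the limit of > 62.5 ug/mL in this assay, at which 2 of the 2 values shown sit, shows. Compound 3 `COc1ccc(/C=N/NC(=O)c2cnc3c(C(F)(F)F)cccc3c2N[C@@H](CSc2ccccc2)CC(=O)N(C)C)cc1O` makes the change (3-hydroxy-4-methoxyphenyl in place of pyridin-3-yl on a carbon with a double bond to nitrogen). For the measured compounds named here, only this unreadable step bears on it, so no step beyond the scatter is expected. Compound 3 is expected at 100 ug/mL (range 40 ug/mL to 300 ug/mL), a step that the limit leaves unreadable from compound 2 to compound 3 expected to stay within the scatter.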

Compound 3, half-maximal inhibitory concentration: > 62.5 ug/mL
Compound 3: only a limit was reported (the forecaster's own chance of this, stated with the estimate: 80%); the middle value is on the limit's open side.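

In this assay, for the compounds shown here, compound 3 gives > 62.5 ug/mL, also a limit of the assay, so no step among compound 1, compound 2 and compound 3 can be read: the limit of > 62.5 ug/mL in this assay, at which 3 of the 3 values shown sit. The compounds shown leave open where their actual values lie and whether these group changes alter them at all.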